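The source may hold more compounds than are shown below. What is called first, only, known or untested is meant among the compounds shown, and "the series" means these compounds.

- Compound 1 `COc1cc2ncnc(Nc3ccc(NC(=O)c4ccc(C)cc4)cc3)c2cc1OC` gives 25000 nM
- Compound 2 `COc1cc2ncnc(Nc3ccc(NC(=O)c4ccccc4F)cc3)c2cc1OC` gives 13000 nM

Both numbers come from a functional assay on HepG2 cells (Homo sapiens) for inhibition, read by MTT assay (on this read-out higher numbers stand for weaker inhibition and lower numbers for stronger inhibition), and both are high on its scale. For the measured compounds named here, only one step has been measured so far, a 1.9-fold lower number from compound 1 to compound 2 (0.28 log units; within the scatter) and so compound 2 cannot be told apart from compound 1, the only other compound measured.

The next compound is compound 3 `COc1cc2ncnc(Nc3ccc(NC(=O)c4ccccc4Cl)cc3)c2cc1OC`. It differs from compound 2 at a single atom: chloro in place of fluoro on an aromatic carbon and the result is chloro in place of fluoro on an aromatic carbon, ortho to a large group.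

Going by the values given here, no measured pair tests this exact swap. The closest evidence is the step from compound 1 to compound 2, which changed the same group on the carbonyl, 4-methylphenyl to 2-fluorophenyl, and stayed within the scatter. A change of one halogen for another at the same spot is therefore expected to give no step beyond the scatter in this assay either. The step expected is no change at the digits printed from compound 2 to compound 3 (within the scatter) in this estimate. For compound 3 the estimated value is 13000 nM with an expected range from 6000 nM to 28000 nM for the measurement.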

Compound 3, half-maximal inhibitory concentration: 26000 nM
Estimate against measurement, compound 3: 2.0-fold (0.30 log units) below; measured number inside the range.
By their numbers in this assay, from the lowest: compounds 2, 1 and 3 (each within the scatter of the next).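

In this assay, for the compounds shown here, replacing fluoro with chloro on an aromatic carbon, ortho to a large group, gives a 2.0-fold higher number from compound 2 to compound 3 (0.30 log units; within the scatter) and is the first direct test of one halogen against another at this position; the two compounds cannot be told apart, even though this step sits right at the edge of the usual variation between repeat measurements. Going by these compounds alone, the comparison with the methyl-bearing compound points the same way: 2-chlorophenyl in place of 4-methylphenyl on the carbonyl gives a 1.0-fold higher number from compound 1 to compound 3 (0.02 log units; within the scatter) and so all three amides remain indistinguishable, with no measured step yet showing that this part of the molecule affects the read-out. No independent measurement is available to explain these numbers.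

Going by these compounds, it remains open whether a more different group in place of the chloro, such as an amine, a carboxylic acid or a longer chain, would produce a step beyond the scatter. It is also unknown whether changing the amide link or the shared core would shift the numbers more than these changes to the aromatic ring have.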